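The compounds below may be only part of what the source reports. "The series", "measured", "known", "first", "only" and "open" are said of these compounds alone.

Notes on the series. The shared core of compound 1 `O=C(/C=C/c1ccc2c(c1)B(O)OC2)c1cccs1` carries a thiophen-2-yl on the carbonyl carbon; in a toxicity assay on WI-38 cells (Homo sapiens) for cytotoxicity, read by MTT assay, with a stated time of 48 h (a lower number here means a stronger inhibitor, a higher number a weaker inhibitor), compound 1 gives 26000 nM. Compound 3 `O=C(/C=C/c1ccc2c(c1)B(O)OC2)c1ccc(F)cc1` carries 4-fluorophenyl there, and in this assay compound 3 gives 7600 nM. Compound 2 `Cn1cccc1C(=O)/C=C/c1ccc2c(c1)B(O)OC2` carries 1-methyl-1H-pyrrol-2-yl. In this assay compound 2 reaches only a limit of the assay, > 100000 nM, not a number; compound 2 sits at the limit of > 100000 nM in this assay, at which 1 of the 3 values shown sits. The measured steps: an at least 3.8-fold higher number from compound 1 to compound 2 (0.58 log units; beyond the scatter); a 3.4-fold lower number from compound 1 to compound 3 (0.53 log units; beyond the scatter); an at least 13-fold lower number from compound 2 to compound 3 (1.11 log units; beyond the scatter).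

Compound 4 `O=C(/C=C/c1ccc2c(c1)B(O)OC2)c1ccc(O)cc1` is not yet measured. Relative to compound 2: 4-hydroxyphenyl in place of 1-methyl-1H-pyrrol-2-yl on a carbonyl carbon. The step that bears most directly is an at least 13-fold lower number from compound 2 to compound 3 (1.11 log units; beyond the scatter), where one six-membered aromatic ring of carbon only likewise enters in place of the same five-membered aromatic ring; the gap between 4-fluorophenyl and 4-hydroxyphenyl is not covered by any measured pair, so the size beyond the limit is uncertain. A large step toward a lower number is therefore expected in this assay, an at least 6.6-fold lower number from compound 2 to compound 4 (0.82 log units; beyond the scatter). Compound 4 is estimated at 15000 nM, with a range from 5000 nM to 60000 nM.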

Compound 4, half-maximal inhibitory concentration: > 100000 nM
Compound 4 was reported as a limit (the forecaster's own chance of this, stated with the estimate: 10%); middle value at least 6.6-fold (0.82 log units) away from the limit.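

In this assay, hydroxy in place of fluoro on an aromatic carbon gives an at least 13-fold higher number from compound 3 to compound 4 (1.11 log units; beyond the scatter), so a six-membered aromatic ring of carbon only on the carbonyl carbon does not by itself bring the lower number seen earlier. The 4-hydroxyphenyl group also falls on the higher side of thiophen-2-yl, with an at least 3.8-fold higher number from compound 1 to compound 4 (0.58 log units; beyond the scatter), so ring size alone does not order this position: compound 3 and compound 4 share the ring type and lie on opposite sides of compound 1. Compound 4 gives a limit and not a number, and its step from compound 2 cannot be read, as both sit at the same limit: the limit of > 100000 nM in this assay, at which 2 of the 4 values shown sit.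

On these data alone, whether an amine, a methoxy or a chloro on that aromatic carbon would stay with fluoro or with hydroxy remains open. As far as these compounds go, how far compound 2 and compound 4 lie beyond the limit also remains open.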